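This account rests on a few compounds, and the source may have more. Where it says the series, first, only, none or still open, it means among the compounds named here.

The measured compounds:
Compound 1, `COc1cc(C(=O)NNC(=S)Nc2csc(-c3ccc(C)cc3)c2)cc(OC)c1OC`, gives 42000 nM.
Compound 2, `COc1ccc(C(=O)NNC(=S)Nc2csc(-c3ccccc3)c2)cc1`, gives 30000 nM.
Compound 3, `COc1cc(OC)cc(C(=O)NNC(=S)Nc2csc(-c3ccc(C)cc3)c2)c1`, gives 38000 nM.

These numbers come from a functional assay on SK-MEL-28 cells (Homo sapiens) for inhibition, read by colorimetric assay and MTT assay, with a stated time of 72 h; a higher number here means a weaker inhibitor, a lower number a stronger inhibitor. For the measured compounds named here, the three values lie close together, and no pair is separated beyond the usual scatter. Compound 3 and compound 1 differ in one place: methoxy in place of hydrogen on an aromatic carbon. The step is a 1.1-fold higher number from compound 3 to compound 1 (0.04 log units; within the scatter). Compound 2 and compound 3 differ in more than one place, and the difference between their cores is not broken down here; their two values are within the scatter of each other.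

Compound 4, `COc1ccc(C(=O)NNC(=S)Nc2csc(-c3ccccc3)c2)cc1OC`, has not yet been measured in this assay. It differs from compound 2 in one place: methoxy in place of hydrogen on an aromatic carbon. Going by the values given here, this is the same kind of change as the one from compound 3 to compound 1, but the surroundings differ: there the entering methoxy sits ortho to two methoxy groups and para to a large group, here ortho to a methoxy group and meta to a large group. Among the compounds with values here, the one measured example of this kind of change stayed within the scatter. For compound 4 a similar step is expected, a 1.1-fold higher number from compound 2 to compound 4 (0.03 log units; within the scatter), because the measured step of a 1.1-fold higher number from compound 3 to compound 1 (0.04 log units; within the scatter) stayed within the scatter. Compound 4 is therefore expected to give 32000 nM in this assay, with a range from 15000 nM to 65000 nM.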

Compound 4, half-maximal inhibitory concentration: 28000 nM
Compound 4: middle estimate off by 1.1-fold (0.06 log units), on the high side, and the stated range covers the measured number.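

In this assay, methoxy in place of hydrogen on the core of compound 2 gives a 1.1-fold lower number from compound 2 to compound 4 (0.03 log units; within the scatter). Set beside the earlier case, the two steps compare as follows: the same change on two cores in this assay, a 1.1-fold higher number (0.04 log units; within the scatter) from compound 3 to compound 1 and a 1.1-fold lower number (0.03 log units; within the scatter) from compound 2 to compound 4, 1.2-fold (0.07 log units) apart, within the scatter of two such steps. For the compounds shown here, on these two cores, then, the change carried over with neither step leaving the scatter, in one surrounding ortho to a methoxy group and meta to a large group and in another ortho to two methoxy groups and para to a large group, but two small steps show only that the change left the number unmoved in these cases, not that it would do so on other cores or at other places on the ring.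

The compounds shown leave open what a hydroxy group, an amine or a carboxylic acid would do on this six-membered aromatic ring. They also leave open whether a longer chain, such as ethoxy in place of methoxy, would stay within the scatter as well.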